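Chlorobenzylidene Thiosemicarbazone Expected Near Its Parent

This account rests on a few compounds, and the source may have more. Where it says the series, first, only, none or still open, it means among the compounds named here.

Compound 1 `CC1=CC[C@@H]([C@@](C)(O)CCCC(C)(C)NC(=S)NN)CC1` is the hydrazide parent of this small set. In a functional assay on NCI-H460 cells (Homo sapiens) for cytotoxicity, read by sulforhodamine B assay (on this read-out lower numbers stand for stronger inhibition of growth and higher numbers for weaker inhibition of growth), compound 1 gives 12800 nM, the highest of the two numbers recorded, though the gap to its nearest neighbour lies within the scatter of this read-out. That neighbour, compound 2 `CC1=CC[C@@H]([C@@](C)(O)CCCC(C)(C)NC(=S)N/N=C\c2ccc([N+](=O)[O-])cc2)CC1`, gives 10100 nM in this assay, so the two values show no separation that can be trusted. Compound 3 `CC1=CC[C@@H]([C@@](C)(O)CCCC(C)(C)NC(=S)N/N=C\c2ccc(Cl)cc2)CC1` has not been measured in this assay. It differs from compound 1 by a group of 9 heavy atoms (7 carbon, 1 nitrogen, 1 chlorine; one six-membered aromatic ring of carbon only) in place of one nitrogen atom, on an amide-type nitrogen. Among the measured compounds shown here, no step between measured compounds is available for this change, so the expectation rests on compound 1 and compound 2 alone, and the step of a 1.6-fold lower number from compound 1 to compound 3 (0.20 log units; within the scatter) is expected to stay close to the scatter, if anything slightly toward a lower number. Compound 3 is accordingly estimated at 8000 nM in this assay, within a range from 2500 nM to 25000 nM.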

Compound 3, concentration for 50% growth inhibition: 8720 nM
Compound 3: middle estimate off by 1.1-fold (0.04 log units), on the low side, within the range that was stated.
By their numbers in this assay, from the lowest: compounds 3, 2 and 1 (each within the scatter of the next).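

In this assay the chloro-bearing aromatic group on the amide-type nitrogen gives a 1.5-fold lower number from compound 1 to compound 3 (0.17 log units; within the scatter) and so, like the nitro-bearing group of compound 2, does not separate from the amino parent beyond the scatter. Among the compounds shown here, on the aromatic ring itself, chloro in place of nitro on an aromatic carbon gives a 1.2-fold lower number from compound 2 to compound 3 (0.06 log units; within the scatter) and thus adds a first step at this site, one that also stays within the scatter. Across these three compounds, then, neither change moves the number by more than repeated measurements would.

On these data alone, whether an amine or a carboxylic acid in place of chloro on that aromatic carbon, or a longer chain in place of the aromatic group on the amide-type nitrogen, would move the number beyond the scatter stays open. No measurement beyond these growth-inhibition values is available to bear on this result.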